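Swapping a bromophenyl for a pyrrole in a urea series

A few compounds are considered here, and "the series" means these few. Any claim that something is new, unique, unknown or untested is made for them only; others in the source may bear on it.

The compounds share a common core, seen in compound 1 `O=C(N/N=C/c1cccc(Br)c1)Nc1ccc(Oc2ccnc3[nH]ccc23)c(F)c1`, and were tested in a functional assay on PC-3 cells (Homo sapiens) for antiproliferative activity, read by MTT assay, with a stated time of 72 h; on this read-out higher numbers stand for weaker inhibition and lower numbers for stronger inhibition. Going by the values given here, compound 1 is the only member with a numerical result; in this assay compound 1 gives 4020 nM. Compound 2 `COc1cc(/C=N/NC(=O)Nc2ccc(Oc3ccnc4[nH]ccc34)c(F)c2)cc(OC)c1OC` is reported in this assay as "not active" (no number reported). Compound 3 `O=C(N/N=C/c1ccc(O)cc1Br)Nc1ccc(Oc2ccnc3[nH]ccc23)cc1` is likewise reported in this assay as "not active" (no number reported). Among the compounds with values here, no step between two measured compounds is given, so nothing about the size of a single change can be read from the measured set.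

Compound 4 `CN(C)CCn1cccc1/C=N/NC(=O)Nc1ccc(Oc2ccnc3[nH]ccc23)c(F)c1` has not been measured. It differs from compound 1 in one place: 1-(2-(dimethylamino)ethyl)-1H-pyrrol-2-yl in place of 3-bromophenyl on a carbon with a double bond to nitrogen. Both compounds retain the fluorine on the core and the hydrazone linkage.

Given that compound 1 is already a weak inhibitor and two other variations of the same core are reported as inactive, a step from compound 1 to compound 4 is expected to be small, in the direction of weaker inhibition, and it may not exceed the usual scatter. The expected step is a 1.6-fold higher number from compound 1 to compound 4 (0.21 log units; within the scatter). Compound 4 is therefore estimated to give 6500 nM in this assay, with a range from 1800 nM to 25000 nM.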

Compound 4, half-maximal inhibitory concentration: 1600 nM
Beside the measured number, compound 4's estimate is 4.1-fold (0.61 log units) above it; the measured number lies below the stated range.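

In this assay, replacing 3-bromophenyl with 1-(2-(dimethylamino)ethyl)-1H-pyrrol-2-yl on a carbon with a double bond to nitrogen gives a 2.5-fold lower number from compound 1 to compound 4 (0.40 log units; beyond the scatter), the first size that can be read for a single change in this series. The step is modest but beyond the usual scatter, and it points toward stronger inhibition, so this place does not depend on keeping the six-membered aromatic ring of carbon or the bromine: compound 4, with a five-membered aromatic ring and a side chain holding two nitrogens in the group overall, still gives a numerical result. Nothing measured on any property of the two groups accompanies this step, so the change in potency stands without an explanation.

The compounds shown leave open whether the gain belongs to the pyrrole ring or to the 2-(dimethylamino)ethyl chain it carries. A plain 1H-pyrrol-2-yl, a morpholine in place of the dimethylamino group, or a longer chain leading to the amine would help to separate these two parts of the change.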